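Phenyl in place of phenethyl: a solubility expectation

The source may hold more compounds than are shown below. What is called first, only, known or untested is meant among the compounds shown, and "the series" means these compounds.

The study follows three measured compounds through a physicochemical assay for solubility, with a stated time of 18 h, at pH 7.4; on this read-out higher numbers stand for higher solubility and lower numbers for lower solubility. Compound 1 `COc1cccc(CNCCCNc2ccnc3cc(Oc4ccccc4)ccc23)c1O` gives 14500 nM in this assay. Compound 2 `c1ccc(CCc2ccc3c(NCCCNCc4ccco4)ccnc3c2)cc1` gives 4200 nM, which is the lowest of the three numbers; compound 1 lies a step above it that is beyond the scatter, and compound 3 `COc1ccc(-c2ccc3c(NCCCNCc4cc(F)ccc4OC)ccnc3c2)cc1`, with 32000 nM, lies furthest above it, also beyond the scatter.

Compound 4 `c1ccc(-c2ccc3c(NCCCNCc4ccco4)ccnc3c2)cc1` has not yet been measured. It differs from compound 2 in one place: phenyl in place of phenethyl on an aromatic carbon. Among the compounds with values here, no measured pair in this set shows the same change, so the size of the step rests on the spread of the three numbers rather than on a direct precedent.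

Compound 4 is expected to reach about 6500 nM, with a range from 2500 nM to 16000 nM. This estimate means a step of a 1.5-fold higher number from compound 2 to compound 4 (0.19 log units; within the scatter) that is expected to be modest and upward, because compound 3 gives 32000 nM as the highest number in the set, and the change is not expected to take compound 4 beyond it.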

Compound 4, solubility: 32000 nM
Compound 4: the middle estimate sits 4.9-fold (0.69 log units) below what was measured, and the stated range ends below it.
By their numbers in this assay, from the lowest: compound 2; then compound 1; then compounds 3 and 4 (each within the scatter of the next).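

This pair gives the set its first direct reading of a single change: in this assay, phenyl in place of phenethyl on this aromatic carbon comes with a 7.6-fold higher number from compound 2 to compound 4 (0.88 log units; beyond the scatter) and nothing else in the structure differs. The position is therefore shown to be one where a change of group can move this read-out by more than the usual scatter, something the three earlier compounds, which differ in several places at once, could not show. No measurement here bears on what lies behind the step.

On these data alone, it remains open whether a benzyl group, a longer chain or a carboxylic acid on this carbon would land nearer compound 2 or compound 4. Also open, as far as these compounds go, is whether the same change would give a step of like size on a compound that differs elsewhere, such as compound 1 or compound 3.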